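The source may report more compounds than this note shows. Statements on the series, on what has been measured and on what is new or still open speak of the compounds shown alone.

Measured compounds:
- compound 1, `COc1cccc(OC)c1OCCNCCOc1ccccc1OCc1ccccc1Cl`, which in a functional assay on PC-3 cells (Homo sapiens) for cytotoxicity, read by sulforhodamine B assay (a higher number here means that more compound is tolerated, a lower number that less compound is tolerated), gives 58900 nM
- compound 2, `COc1cccc(OC)c1OCCNCCOc1ccccc1OCc1ccc(C)cc1`, which in this assay gives 61700 nM

Compound 2 stands at the higher of the two numbers, but its distance from compound 1, a 1.0-fold higher number from compound 1 to compound 2 (0.02 log units; within the scatter), lies within the scatter, so the two cannot be told apart. Compound 3, `COc1cccc(OC)c1OCCNCCOc1ccccc1OCc1ccccc1[N+](=O)[O-]`, differs from compound 2 by 2-nitrophenyl in place of 4-methylphenyl on a saturated chain carbon bound to an oxygen on an aromatic ring. For the measured compounds named here, the one measured step touching the same place is the one from compound 1 to compound 2, a 1.0-fold higher number from compound 1 to compound 2 (0.02 log units; within the scatter), and it changed nothing beyond the scatter when one aryl group was swapped for another at this saturated chain carbon. On that basis compound 3 is expected to stay close to compound 2, with a step of a 1.0-fold lower number from compound 2 to compound 3 (0.01 log units; within the scatter) in this assay, that is, no shift beyond the scatter. Compound 3 is therefore estimated at 60000 nM, with a range from 30000 nM to 120000 nM.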

Compound 3, concentration lethal to 50% of the cells: 95500 nM
For compound 3 the middle estimate is 1.6-fold (0.20 log units) below the measured one; the measured number falls inside the stated range.
By their numbers in this assay, from the lowest: compounds 1, 2 and 3 (each within the scatter of the next).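

In this assay, the 2-nitrophenyl group of compound 3 takes the place of the 4-methylphenyl group with no shift beyond the scatter (a 1.5-fold higher number from compound 2 to compound 3 (0.19 log units; within the scatter)), even though it brings more heavy atoms and two hydrogen-bond acceptors where the 4-methylphenyl group has none. Replacing chloro with nitro on an aromatic carbon also stays within the scatter (a 1.6-fold higher number from compound 1 to compound 3 (0.21 log units; within the scatter)), so at this saturated chain carbon all three substituted phenyl groups, including the new nitro-bearing one, give numbers that cannot be told apart. No measurement at hand explains this sameness.

Going by these compounds, it remains open whether a phenyl ring carrying an amine or a carboxylic acid would also leave the number unmoved. The same question stands for a cyclohexyl group in place of the aromatic ring.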